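The source may hold more compounds than are shown below. What is called first, only, known or untested is meant among the compounds shown, and "the series" means these compounds.

Measured compounds:
Compound 1, `O=[N+]([O-])c1ccc(Cn2cc(COc3cccc([N+](=O)[O-])c3)nn2)cc1`: 17.1 ug/mL
Compound 2, `O=[N+]([O-])c1cccc(OCc2cn(Cc3ccc(Br)cc3)nn2)c1`: 29.4 ug/mL
Compound 3, `O=[N+]([O-])c1ccc(Cn2cc(COc3ccc([N+](=O)[O-])cc3I)nn2)cc1`: 16.8 ug/mL

All three were read in a physicochemical assay, read by spectrophotometry, with a stated time of 30 min; on this read-out lower numbers stand for stronger inhibition and higher numbers for weaker inhibition. Compound 1 and compound 2 share one core and differ in a single place: bromo in place of nitro on an aromatic carbon. The step this made is a 1.7-fold higher number from compound 1 to compound 2 (0.24 log units; within the scatter). Compound 3 carries a different core, and the difference between the two cores is not broken down here; in this assay compound 3 gives 16.8 ug/mL, which sits close to compound 1 and within the scatter of compound 2 as well.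

Compound 4, `O=[N+]([O-])c1ccc(OCc2cn(Cc3ccc(Br)cc3)nn2)c(I)c1`, is not yet measured. It differs from compound 3 in the same way that compound 2 differs from compound 1: bromo in place of nitro on an aromatic carbon. The place line reads the same in both pairs, so this is taken as the same change made on a second core. Among the compounds with values here, because the one earlier instance, a 1.7-fold higher number from compound 1 to compound 2 (0.24 log units; within the scatter), stayed within the scatter, the expectation for compound 4 is a step of similar size and direction, that is a 1.7-fold higher number from compound 3 to compound 4 (0.22 log units; within the scatter), set against the measured value of compound 3. Compound 4 is therefore estimated at 28 ug/mL, with a likely range from 15 ug/mL to 50 ug/mL. The estimate rests on a single prior step, so it is held loosely.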

Compound 4, half-maximal inhibitory concentration: 18.5 ug/mL
Estimate against measurement, compound 4: 1.5-fold (0.18 log units) above; low and high end bracket the measured number.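

In this assay the change from 4-nitrophenyl to 4-bromophenyl gives a 1.1-fold higher number from compound 3 to compound 4 (0.04 log units; within the scatter) on one core and a 1.7-fold higher number from compound 1 to compound 2 (0.24 log units; within the scatter) on the other, so in both pairs the step stays within the scatter. This shows that the two cores agree in having no step beyond the scatter, but it gives the change no reliable direction, and two pairs do not show that the step would stay this small on any further core. No measurement shown here bears on the reason for this result.

On these data alone, whether an amine or a carboxylic acid on that same aromatic carbon would also leave the number within the scatter remains open. Also open, as far as these compounds go, is whether the agreement between the two cores would hold on any read-out other than this assay, since all four compounds are compared on this one alone.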